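A few compounds are considered here, and "the series" means these few. Any claim that something is new, unique, unknown or untested is made for them only; others in the source may bear on it.

Of the compounds shown here, three sharing one core have been tested in a functional assay on HUVEC cells (Homo sapiens) for antiproliferative activity, read by MTT assay, with a stated time of 24 h; a lower number here means a stronger inhibitor, a higher number a weaker inhibitor: compound 1 `C=CCOc1ccc2c(=O)c(-c3cc(OC)c(OC)cc3OC)coc2c1`, compound 2 `COc1cc(OC)c(-c2coc3cc(OCc4cccc(Br)c4)ccc3c2=O)cc1OC` and compound 3 `COc1cc(OC)c(-c2coc3cc(OCc4ccc(C(F)(F)F)cc4)ccc3c2=O)cc1OC`. They differ only in the group on a saturated chain carbon bound to an oxygen on an aromatic ring. Compound 1 gives > 10000 nM as its result, which is a limit of the assay and not a number. Compound 2 gives > 10000 nM, again a limit. Compound 3, the starting point here, also gives only a limit, > 10000 nM in this assay. All three results therefore sit together: the limit of > 10000 nM in this assay, at which 3 of the 3 values shown sit.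

Compound 4 `COc1cc(OC)c(-c2coc3cc(OCc4cccc(C(F)(F)F)c4)ccc3c2=O)cc1OC` carries 3-(trifluoromethyl)phenyl in place of 4-(trifluoromethyl)phenyl at that same place, and nothing else changes: 3-(trifluoromethyl)phenyl in place of 4-(trifluoromethyl)phenyl on a saturated chain carbon bound to an oxygen on an aromatic ring. The two have the same atoms, joined differently.

The closest measured comparison is a step that the two limits leave unreadable from compound 2 to compound 3, which also exchanges one substituted phenyl for another. The other two comparisons are a step that the two limits leave unreadable from compound 1 to compound 2 and a step that the two limits leave unreadable from compound 1 to compound 3. None of these has a readable size, so they favour no direction, and no change beyond the scatter is expected. The expected step is a step that the limit leaves unreadable from compound 3 to compound 4 in this assay. For compound 4 the estimated value is 12000 nM, with an expected range from 4000 nM to 30000 nM and another limit as the likeliest report.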

Compound 4, half-maximal inhibitory concentration: > 10000 nM
Compound 4: no number, only a limit; the forecaster's own chance of this, stated with the estimate: 85%; the middle value does not contradict the limit.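

In this assay compound 4 gives > 10000 nM, which is a limit and not a number. The steps to compound 4 from compound 1, compound 2 and compound 3 therefore cannot be read, and all results sit together: the limit of > 10000 nM in this assay, at which 4 of the 4 values shown sit.

The compounds shown leave open whether any group at this place gives a real number in this assay, and how 3-(trifluoromethyl)phenyl and 4-(trifluoromethyl)phenyl truly compare.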